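This account rests on a few compounds, and the source may have more. Where it says the series, first, only, none or still open, it means among the compounds named here.

Three compounds share one core and differ only in the group on the aromatic nitrogen. In a functional assay on the whole organism for antagonist activity, with Rattus norvegicus as the target (a higher number here means that more compound is needed for the effect, a lower number that less compound is needed), compound 1 `CCCCn1cnc2c(N(C)C)ncnc21` gives 10 mg/kg, compound 2 `CC(C)n1cnc2c(N(C)C)ncnc21` gives 11 mg/kg, and compound 3 `CN(C)c1ncnc2c1ncn2C1CC1` gives 9 mg/kg. Compound 3 stands at the lowest of the three numbers, though its gaps to compound 1 and to compound 2 are both within the scatter. The steps of a 1.1-fold higher number from compound 1 to compound 2 (0.04 log units; within the scatter), a 1.1-fold lower number from compound 1 to compound 3 (0.05 log units; within the scatter) and a 1.2-fold lower number from compound 2 to compound 3 (0.09 log units; within the scatter) all lie within the scatter.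

Compound 4 `c1nc(NC2CC2)c2ncn(C3CC3)c2n1` differs from compound 3 by cyclopropylamino in place of dimethylamino on an aromatic carbon. Within the data shown here, none of the measured steps touches this position; each of them exchanges the group on the aromatic nitrogen, and each stayed within the scatter in this assay. Among the measured compounds shown here, no measured step therefore bears directly on the change from compound 3 to compound 4, and the expectation rests only on the narrow spread of the three values. Compound 4 is expected to give 9 mg/kg, within 3 mg/kg to 30 mg/kg. The step of no change at the digits printed from compound 3 to compound 4 (within the scatter) is expected to be small, with no direction foreseen beyond the scatter.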

Compound 4, dose for half-maximal effect: 4.5 mg/kg
Beside the measured number, compound 4's estimate is 2.0-fold (0.30 log units) above it; measured number inside the range.
By their numbers in this assay, from the lowest: compounds 4, 3, 1 and 2 (each within the scatter of the next, the first and the last beyond it).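

Compound 4 is the first of these compounds to vary the group on an aromatic carbon of the six-membered aromatic ring, as the earlier steps exchanged only the group on the aromatic nitrogen. Cyclopropylamino in place of dimethylamino brings in a three-membered ring and a hydrogen-bond donor, and it gives a 2.0-fold lower number from compound 3 to compound 4 (0.30 log units; within the scatter) in this assay, so this exchange at the new position stays within the scatter, as the earlier exchanges at the aromatic nitrogen did. Nothing available here bears on the reason for this result.

The compounds shown leave open whether a simple amino group, methylamino or a ring amine such as morpholine at this position would stay within the scatter of compound 4. They also leave open how cyclopropylamino behaves with butyl or isopropyl on the aromatic nitrogen.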